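The source may hold more compounds than are shown below. What is called first, only, known or untested is meant among the compounds shown, and "the series" means these compounds.

The measured compounds in a functional assay on HeLa cells (Homo sapiens) for inhibition, read by MTT assay (a higher number here means a weaker inhibitor, a lower number a stronger inhibitor), are these:
Compound 1 `CCCCCCCCn1cc(/C=C/C(=O)c2ccc(NC(=O)CN3CCN(C(=O)OC(C)(C)C)CC3)cc2)nn1` gives 32100 nM.
Compound 2 `COc1ccccc1N1CCN(CC(=O)Nc2ccc(C(=O)/C=C/c3cn(Cc4ccc(Br)cc4)nn3)cc2)CC1` gives 26400 nM.
Compound 3 `O=C(CN1CCN(c2ccccc2)CC1)Nc1ccc(C(=O)/C=C/c2cn(Cc3ccc(Br)cc3)nn2)cc1` gives 79700 nM.

Compound 3 stands highest of the three numbers, and its gap to each of the other two lies beyond the scatter. For the measured compounds named here, the single step between compounds that differ in one place is a 3.0-fold higher number from compound 2 to compound 3 (0.48 log units; beyond the scatter), a modest move toward weaker inhibition on loss of the methoxy group.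

Compound 4 `CC(C)(C)OC(=O)N1CCN(CC(=O)Nc2ccc(C(=O)/C=C/c3cn(Cc4ccc(Br)cc4)nn3)cc2)CC1` differs from compound 3 by tert-butoxycarbonyl in place of phenyl on an amine nitrogen in a ring. Going by the values given here, no measured pair shows exactly this exchange, so no step bears on it directly. Compound 1 carries the same tert-butoxycarbonyl on the ring nitrogen, yet it differs from compound 3 at a second site as well, so the two only show that compound 1 sits lower than compound 3 in this assay. On that indirect ground a modest step toward a lower number is expected, a 2.3-fold lower number from compound 3 to compound 4 (0.36 log units; beyond the scatter). Compound 4 is therefore estimated at 35000 nM, with an expected range from 12000 nM to 100000 nM.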

Compound 4, half-maximal inhibitory concentration: 18900 nM
Compound 4: the middle estimate sits 1.9-fold (0.27 log units) above what was measured, within the range that was stated.
By their numbers in this assay, from the lowest: compounds 4, 2 and 1 (each within the scatter of the next); then compound 3.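

In this assay, the ring amine nitrogen accepts tert-butoxycarbonyl, which has no ring, in place of phenyl, a change that gives a 4.2-fold lower number from compound 3 to compound 4 (0.62 log units; beyond the scatter). The same group in place of 2-methoxyphenyl gives a 1.4-fold lower number from compound 2 to compound 4 (0.15 log units; within the scatter), which is within the scatter, so among the three groups on this nitrogen only the plain phenyl of compound 3 stands apart. With tert-butoxycarbonyl held on that nitrogen, 4-bromophenyl in place of heptyl gives a 1.7-fold lower number from compound 1 to compound 4 (0.23 log units; within the scatter), also within the scatter, so this exchange at the other site leaves the number unresolved.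

Still open, going by these compounds, is how an acetyl group, a methyl group or the free amine on this nitrogen would read. No measurement at hand accounts for these differences.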